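This account rests on a few compounds, and the source may have more. Where it says the series, first, only, none or still open, it means among the compounds named here.

The two measured compounds share one core. In a functional assay on A549 cells (Homo sapiens) for inhibition, read by MTT assay, with a stated time of 72 h (a lower number here means a stronger inhibitor, a higher number a weaker inhibitor), compound 1 `CN(C(=O)NC(=O)c1ccc(Cl)cc1Cl)c1nc(C(F)(F)F)c(C(=O)N/N=C/c2cccc(C(F)(F)F)c2)s1` gives 10.6 ug/mL, while in this assay compound 2 `CN(C(=O)NC(=O)c1c(F)cccc1F)c1nc(C(F)(F)F)c(C(=O)N/N=C/c2cccc(C(F)(F)F)c2)s1` gives 27.6 ug/mL. Compound 2 thus stands at the higher of the two numbers shown, with compound 1 as its only neighbour, the gap between them being a 2.6-fold higher number from compound 1 to compound 2 (0.42 log units; beyond the scatter). Compound 3 `Cc1nc(N(C)C(=O)NC(=O)c2c(F)cccc2F)sc1C(=O)N/N=C/c1cccc(C(F)(F)F)c1` differs from compound 2 at a single place: methyl in place of trifluoromethyl on an aromatic carbon. Within the data shown here, the one measured step concerns the group on the carbonyl carbon and so does not speak directly to a change on the five-membered aromatic ring with one nitrogen and one sulfur; no measured pair tests that place. Among the measured compounds shown here, with no comparable step to lean on, the expected step of a 1.0-fold higher number from compound 2 to compound 3 (0.01 log units; within the scatter) in this assay is taken as none beyond the scatter, with a wide range to either side. Compound 3 is therefore estimated at 28 ug/mL, between 10 ug/mL and 75 ug/mL.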

Compound 3, half-maximal inhibitory concentration: 30.3 ug/mL
Compound 3: middle estimate off by 1.1-fold (0.03 log units), on the low side; measured number inside the range.
By their numbers in this assay, from the lowest: compound 1; then compounds 2 and 3 (each within the scatter of the next).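

In this assay, trifluoromethyl and methyl on the aromatic carbon next to the ring nitrogen cannot be told apart: the exchange gives a 1.1-fold higher number from compound 2 to compound 3 (0.04 log units; within the scatter). Among these compounds, this is the first measured step at this place on the ring, and it shows that a group of 4 heavy atoms and a group of 1 heavy atom can sit there with no difference beyond the scatter when 2,6-difluorophenyl stands on the carbonyl carbon. No measurement offered here accounts for this result.

The compounds shown leave open whether the same holds with the 2,4-dichlorophenyl group of compound 1 on the carbonyl carbon. They also leave open how an amine, a carboxylic acid or a longer chain such as propyl would read at this ring carbon.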